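The source may hold more compounds than are shown below. What is called first, only, known or untested is meant among the compounds shown, and "the series" means these compounds.

Three compounds have been measured in a functional assay on cells for agonist activity at C-X-C chemokine receptor type 4 (Homo sapiens), read by fluorescence and calcium flux, with a stated time of 90 s (a higher number here means that more compound is needed for the effect, a lower number that less compound is needed), and each gives only a limit of the assay rather than a number:

Compound 1 `c1cncc(CNCCCCN(C[C@H]2Cc3ccccc3CN2)[C@H]2CCCc3cccnc32)c1` gives > 30000 nM.
Compound 2 `c1ccc2c(c1)CN[C@@H](CN(CCCCNCC1CCSCC1)[C@H]1CCCc3cccnc31)C2` gives > 30000 nM.
Compound 3 `CC(C)(CN)CCN(C[C@H]1Cc2ccccc2CN1)[C@H]1CCCc2cccnc21` gives > 30000 nM.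

Compound 3 thus stands at the limit that all three shown values share (the limit of > 30000 nM in this assay, at which 3 of the 3 values shown sit). Compound 4 `C(=C/CN(C[C@H]1Cc2ccccc2CN1)[C@H]1CCCc2cccnc21)\CNCc1cccnc1` differs from compound 3 by a group of 11 heavy atoms (9 carbon, 2 nitrogen; one six-membered aromatic ring with 1 hetero atom) in place of a group of 6 heavy atoms (5 carbon, 1 nitrogen; no ring), on a saturated chain carbon bound to an amine nitrogen. The measured steps that touch compound 3, a step that the two limits leave unreadable from compound 1 to compound 3 and a step that the two limits leave unreadable from compound 2 to compound 3, run between two limits, so their size cannot be read; the same holds for a step that the two limits leave unreadable from compound 1 to compound 2. Going by the values given here, no measured step therefore points in either direction for this assay. Compound 4 is expected to sit at or near the same limit, with an estimated step of a number no higher from compound 3 to compound 4 (the limit leaves the size open). The estimate for compound 4 is 30000 nM, within 5000 nM to 100000 nM.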

Compound 4, half-maximal effective concentration: > 30000 nM
Compound 4 ended at the assay's limit (the forecaster's own chance of this, stated with the estimate: 80%); the middle value sits exactly at the limit.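

Compound 4 also gives only a limit, so its steps from compound 1, compound 2 and compound 3 cannot be read: the limit of > 30000 nM in this assay, at which 4 of the 4 values shown sit. The compounds shown leave open how far each lies past this limit in this assay and which change would give a readable value.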